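The source may hold more compounds than are shown below. What is called first, only, known or untested is meant among the compounds shown, and "the series" means these compounds.

Measured so far in a functional assay on L6 cells (Rattus norvegicus) for inhibition (a higher number here means a weaker inhibitor, a lower number a stronger inhibitor), for each compound:
- compound 1 `CC(C)c1c(C(=O)N(C)Cc2ccccc2)nn(-c2ccc(F)cc2)c1CC[C@@H](O)C[C@@H](O)CC(=O)O` gives 2870 nM
- compound 2 `Cc1ccc(CNC(=O)c2nn(-c3ccc(F)cc3)c(CC[C@@H](O)C[C@@H](O)CC(=O)O)c2C(C)C)cc1` gives 800 nM
- compound 3 `CC(C)c1c(C(=O)NCC2CCCCC2)nn(-c2ccc(F)cc2)c1OC[C@@H](O)C[C@@H](O)CC(=O)O` gives "not determined" (no result reported)

Compound 3 has no number, so it offers no starting point. Compound 4 `CC(C)c1c(C(=O)N2CCC[C@H](c3ccccc3)C2)nn(-c2ccc(F)cc2)c1OC[C@@H](O)C[C@@H](O)CC(=O)O` differs from it at the amide: 3-phenylpiperidin-1-yl in place of (cyclohexylmethyl)amino on a carbonyl carbon. Among the compounds with values here, the only measured amide swap, (4-methylbenzyl)amino in place of benzyl(methyl)amino, gave a 3.6-fold lower number from compound 1 to compound 2 (0.55 log units; beyond the scatter) in this assay as a modest change. Those two compounds carry a different chain on the shared core, so they are only a loose guide. No step size or direction can be expected from compound 3. Like compound 1 at 2870 nM in the same test, compound 4 lacks the amide hydrogen, and a value in that general region seems likely. Compound 4 is expected near 1200 nM, with an estimated range of 200 nM to 6000 nM overall.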

Compound 4, half-maximal inhibitory concentration: 1110 nM
Estimate against measurement, compound 4: 1.1-fold (0.03 log units) above, and the stated range covers the measured number.
By their numbers in this assay, from the lowest: compounds 2 and 4 (each within the scatter of the next); then compound 1.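

Within the data shown here, compound 3 has no number in this assay, so no step to compound 4 at 1110 nM can be read. On these data alone, how swapping (cyclohexylmethyl)amino for 3-phenylpiperidin-1-yl shifts the number stays open, and no evidence here bears on it.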